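The source may hold more compounds than are shown below. What is called first, only, known or untested is meant among the compounds shown, and "the series" means these compounds.

Compound 1 `COc1cc2c(Oc3ccc(NC(=O)c4nn(-c5ccc(Br)cc5)c(=O)c5ccccc45)cc3F)ccnc2cc1OCCCN1CCN(C)CC1`: 350 nM
Compound 2 `COc1cc2c(Oc3ccc(NC(=O)c4nn(-c5ccccc5Br)c(=O)c5ccccc45)cc3F)ccnc2cc1OCCCN1CCN(C)CC1`: 400 nM
Compound 3 `COc1cc2c(Oc3ccc(NC(=O)c4nn(-c5ccc([N+](=O)[O-])cc5)c(=O)c5ccccc45)cc3F)ccnc2cc1OCCCN1CCN(C)CC1`: 1320 nM

All three were measured in a functional assay on MKN-45 cells (Homo sapiens) for cytotoxicity, read by MTT assay, with a stated time of 72 h; on this read-out higher numbers stand for weaker inhibition and lower numbers for stronger inhibition. Compound 3 stands at the highest of the three numbers, set apart by a 3.8-fold higher number from compound 1 to compound 3 (0.58 log units; beyond the scatter) and by a 3.3-fold higher number from compound 2 to compound 3 (0.52 log units; beyond the scatter), whereas a 1.1-fold higher number from compound 1 to compound 2 (0.06 log units; within the scatter) lies within the scatter. Compound 4 `COc1cc2c(Oc3ccc(NC(=O)c4nn(-c5ccc([N+](=O)[O-])cc5)c(=O)c5ccccc45)cc3F)ccnc2cc1OCCCN1CCCCC1` differs from compound 3 by piperidin-1-yl in place of 4-methylpiperazin-1-yl on a saturated chain carbon, three bonds along the chain from an oxygen on an aromatic ring. Among the measured compounds shown here, none of the measured steps bears on this change: each of them alters the group on the aromatic nitrogen, and the chain end is shared by all three measured compounds. With nothing to guide a direction, compound 4 is expected to stay close to compound 3, with a 1.0-fold lower number from compound 3 to compound 4 (0.01 log units; within the scatter) within the scatter. Compound 4 is therefore estimated at 1300 nM in this assay, between 500 nM and 3500 nM.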

Compound 4, half-maximal inhibitory concentration: 1140 nM
Beside the measured number, compound 4's estimate is 1.1-fold (0.06 log units) above it, within the range that was stated.
By their numbers in this assay, from the lowest: compounds 1 and 2 (each within the scatter of the next); then compounds 4 and 3 (each within the scatter of the next).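

Among the compounds shown here, at the chain end, which the earlier compounds all shared, 3-(piperidin-1-yl)propyl in place of 3-(4-methylpiperazin-1-yl)propyl gives in this assay a 1.2-fold lower number from compound 3 to compound 4 (0.06 log units; within the scatter) and so no change that can be told from the scatter. With the 4-nitrophenyl group held constant, this position therefore accepts a ring with one hetero atom in place of a ring with two without a measurable shift. Nothing available explains this result. As far as these compounds go, whether the same holds alongside the 4-bromophenyl group of compound 1 remains open, as does the outcome with a morpholine ring, an open-chain dimethylamine or a shorter chain at this position.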